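The source may hold more compounds than are shown below. What is called first, only, known or untested is meant among the compounds shown, and "the series" means these compounds.

In a functional assay on L6 cells (Rattus norvegicus) for inhibition (on this read-out higher numbers stand for weaker inhibition and lower numbers for stronger inhibition), compound 1 (`Cc1ccc(CNC(=O)c2nn(-c3ccc(F)cc3)c(CC[C@@H](O)C[C@@H](O)CC(=O)O)c2C(C)C)cc1`) gives 800 nM and compound 2 (`Cc1cccc(CNC(=O)c2nn(-c3ccc(F)cc3)c(OC[C@@H](O)C[C@@H](O)CC(=O)O)c2C(C)C)c1`) gives 280 nM, the lower of the two numbers, with a gap beyond the scatter. Compound 3 (`COCc1cccc(CNC(=O)c2nn(-c3ccc(F)cc3)c(OC[C@@H](O)C[C@@H](O)CC(=O)O)c2C(C)C)c1`) differs from compound 2 in one place: methoxy in place of hydrogen on a saturated chain carbon bound to an aromatic carbon, turning 3-methylbenzyl into 3-(methoxymethyl)benzyl. Among the measured compounds shown here, no measured pair shows this change, so only a small move toward weaker inhibition in this assay is expected, possibly none beyond the scatter. The expected step is a 1.3-fold higher number from compound 2 to compound 3 (0.10 log units; within the scatter). Compound 3 is estimated at 350 nM, with an expected range of 120 nM to 1000 nM.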

Compound 3, half-maximal inhibitory concentration: 3600 nM
Estimate against measurement, compound 3: 10-fold (1.01 log units) below, and the stated range ends below it.
By their numbers in this assay, from the lowest: compound 2; then compound 1; then compound 3.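

In this assay the methyl of the 3-methylbenzyl group turns out not to be a place that tolerates any change: turning it into 3-(methoxymethyl)benzyl gives a 13-fold higher number from compound 2 to compound 3 (1.11 log units; beyond the scatter), a large move toward weaker inhibition from a methoxy of only 2 heavy atoms. Among the compounds shown here, this is the first step between compounds that differ in one place, since the earlier pair offered none. Nothing available explains the size of this step.

On these data alone, whether the oxygen or the added chain length carries the loss stays open. A 3-ethylbenzyl, 3-propylbenzyl or 3-(aminomethyl)benzyl group would bear on that question.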